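The compounds below may be only part of what the source reports. "The series", "measured", "known", "first", "only" and "open" are said of these compounds alone.

Measured so far:
- Compound 1, `CCCOc1ccc(C(=O)NNc2c(Br)cccc2Br)cc1`: > 100000 nM
- Compound 2, `Cc1ccc(C(=O)NNc2c(Cl)cccc2Cl)cc1`: > 100000 nM
- Compound 3, `CN(C)c1ccc(C(=O)NNc2c(Br)cc(Br)cc2Br)cc1`: 20300 nM

All three were tested in a toxicity assay on MDCK cells (Canis lupus familiaris) for cytotoxicity, read by CCK-8 assay, with a stated time of 48 h; a higher number here means that more compound is tolerated, a lower number that less compound is tolerated. For compound 1 the result is a limit rather than a number, > 100000 nM, meaning the assay could not place a value within its range. Compound 2 likewise gives only a limit, > 100000 nM. For the measured compounds named here, compound 3 is the one compound of the three with an actual number, 20300 nM. Going by the values given here, compound 1 therefore stands at the limit of > 100000 nM in this assay, at which 2 of the 3 values shown sit, and no measured step to another compound can be drawn from it.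

The unmeasured compound 4, `O=C(O)c1ccc(C(=O)NNc2c(Br)cccc2Br)cc1`, keeps the core of compound 1 and differs in one place: carboxy in place of propoxy on an aromatic carbon. Both the propoxy group and the carboxy group carry no net charge, and the rest of the molecule is unchanged. Among the compounds with values here, with no measured step to guide it, the expected step from compound 1 to compound 4 in this assay is a step that the limit leaves unreadable from compound 1 to compound 4, that is, none beyond the usual scatter. Compound 4 is thus expected to give roughly 150000 nM, within a range from 60000 nM to 400000 nM, and most likely the assay will again report only a limit.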

Compound 4, half-maximal cytotoxic concentration: > 100000 nM
Compound 4 gave a limit, no number; the forecaster's own chance of this, stated with the estimate: 75%; the middle value lies beyond the limit too.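

For the compounds shown here, compound 1 and compound 4 each give only a limit, not a number, so no step between them can be read: the limit of > 100000 nM in this assay, at which 3 of the 4 values shown sit.

In this assay, as far as these compounds go, it remains open whether carboxy in place of propoxy on an aromatic carbon changes how much compound is tolerated, and by how much.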